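A few compounds are considered here, and "the series" means these few. Any claim that something is new, unique, unknown or untested is made for them only; others in the source may bear on it.

Among the measured compounds shown here, in an in vitro ADME assay on S9 fraction from HCT-116 cells (Homo sapiens) for metabolic stability, using NADPH, in the presence of a further agent that is not named here (a higher number here means that the compound lasts longer, a lower number that the compound disappears faster), compound 1 `O=C(c1ccc(-c2nc(Cc3cccs3)no2)s1)C(F)(F)F` gives 0.583 h, the only exact number so far. For the measured compounds named here, the one other compound measured is compound 2 `O=C(c1ccc(-c2nc(-c3ccc(F)cc3F)no2)s1)C(F)(F)F`, which gives > 2 h. That value is a limit of the assay and not a number.

Compound 3 `O=C(c1ccc(-c2nc(CS(=O)(=O)c3cccs3)no2)s1)C(F)(F)F` has not yet been measured. It keeps the core of compound 1 and differs in one place: (thiophen-2-yl)sulfonyl in place of thiophen-2-yl on a saturated chain carbon bound to an aromatic carbon. In words, this is (thiophen-2-yl)sulfonyl in place of thiophen-2-yl on a saturated chain carbon bound to an aromatic carbon.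

Going by the values given here, only one measured step bears on this change: an at least 3.4-fold higher number from compound 1 to compound 2 (0.53 log units; beyond the scatter). That step shows that a change in this side group can move the result in this assay beyond the scatter. However, it replaces the whole (thiophen-2-yl)methyl with 2,4-difluorophenyl, so it is weak evidence for the smaller change in compound 3. With so little to go on, only a small upward step is expected, one that stays within the scatter: the estimate is a 1.4-fold higher number from compound 1 to compound 3 (0.14 log units; within the scatter). For compound 3, the expected half-life is 0.8 h, with an estimated range from 0.35 h to 1.9 h.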

Compound 3, half-life: 0.733 h
Estimate against measurement, compound 3: 1.1-fold (0.04 log units) above; low and high end bracket the measured number.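

In this assay, putting (thiophen-2-yl)sulfonyl in place of thiophen-2-yl on this saturated chain carbon gives a 1.3-fold higher number from compound 1 to compound 3 (0.10 log units; within the scatter) and so leaves the half-life within the scatter. The earlier step replaced the whole side group, ring and chain carbon together, and could not show what a change limited to the link between that carbon and the thiophene ring would do; here the thiophene ring and chain carbon both stay, and the larger group, with 3 hydrogen-bond acceptors in place of 1, brings no change that can be told from the scatter. So this position accepts a sulfonyl link in this assay without a measurable loss or gain, at least for this one group, and nothing shown explains why.

The compounds shown leave open whether an amine, a carboxylic acid or a longer chain on this same carbon would shift the half-life beyond the scatter, and whether a 2,4-difluorophenyl group carried on the sulfonyl link would behave as thiophene does. How long compound 2 lasts also stays open, since its value is a limit and not a number: the limit of > 2 h in this assay, at which 1 of the 3 values shown sits.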